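Methoxycarbonyl in Place of Carbamoyl on the Benzyl Group

This account rests on a few compounds, and the source may have more. Where it says the series, first, only, none or still open, it means among the compounds named here.

Compound 1 `NC(=O)CCCCN(Cc1cccc(C(N)=O)c1)C[C@H]1O[C@@H](n2cnc3c(N)ncnc32)[C@H](O)[C@@H]1O`: in an assay on cells for inhibition of Nicotinamide N-methyltransferase (Homo sapiens), with stated times of 10 min and 30 min (a higher number here means a weaker inhibitor, a lower number a stronger inhibitor), compound 1 gives > 250000 nM, a limit.
Compound 2 `NC(=O)c1cccc(CN(CCCC(=O)O)C[C@H]2O[C@@H](n3cnc4c(N)ncnc43)[C@H](O)[C@@H]2O)c1`: in this assay compound 2 gives > 250000 nM, again a limit.
Compound 3 `NC(=O)c1cccc(CN(CCCCC(=O)O)C[C@H]2O[C@@H](n3cnc4c(N)ncnc43)[C@H](O)[C@@H]2O)c1`: in this assay compound 3 gives > 250000 nM, again a limit.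

Compound 3 thus stands at the limit of this assay, where all three measured compounds sit (the limit of > 250000 nM in this assay, at which 3 of the 3 values shown sit). Compound 4 `COC(=O)c1cccc(CN(CCCCC(=O)O)C[C@H]2O[C@@H](n3cnc4c(N)ncnc43)[C@H](O)[C@@H]2O)c1` differs from compound 3 by methoxy in place of amino on a carbonyl carbon. Among the measured compounds shown here, the measured steps a step that the two limits leave unreadable from compound 1 to compound 2, a step that the two limits leave unreadable from compound 1 to compound 3 and a step that the two limits leave unreadable from compound 2 to compound 3 run between limits and give no readable size, and none of them touches the carbamoyl group, so no measured step bears directly on this change. The step from compound 3 to compound 4 in this assay is therefore expected to be a step that the limit leaves unreadable from compound 3 to compound 4, with the greatest chance that the assay again reports only a limit. Compound 4 is estimated at 300000 nM, within 80000 nM to 1000000 nM.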

Compound 4, half-maximal inhibitory concentration: > 250000 nM
Compound 4: no number, only a limit; the forecaster's own chance of this, stated with the estimate: 85%; the middle value is on the limit's open side.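

In this assay compound 4 gives > 250000 nM, a limit, and compound 3 also gives only a limit, so no size can be read for the step between them. The compounds shown leave open whether carbamoyl and methoxycarbonyl on the benzyl group differ at all in inhibition, and how strongly any of these compounds inhibits: the limit of > 250000 nM in this assay, at which 4 of the 4 values shown sit.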